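This account rests on a few compounds, and the source may have more. Where it says the series, first, only, none or still open, it means among the compounds named here.

Three compounds built on a shared core were measured in a functional assay, with a stated time of 12 h, tested at 100 uM; a lower number here means less inhibition, a higher number more inhibition at the concentration tested (going by the name of the read-out). Compound 1 `COc1ccc(C=C2C(=O)OC(C)(C)OC2=O)c(OC)c1OC` gives 13%. Compound 2 `COc1cc(C=C2C(=O)OC(C)(C)OC2=O)ccc1O` gives 92.6%, and compound 3 `CCOc1cc(C=C2C(=O)OC(C)(C)OC2=O)ccc1O` gives 95.6%. Among these three numbers compound 2 stands second highest: its nearest neighbour is reached by the step of a number 3 percentage points higher from compound 2 to compound 3 (within the scatter), while its furthest, compound 1, differs from it in more than one place. Compound 4 `COc1cc(C=C2C(=O)OC(C)(C)OC2=O)ccc1OCc1ccccc1` has not yet been measured in this assay. It differs from compound 2 by benzyl in place of hydrogen on an oxygen on an aromatic ring. Among the measured compounds shown here, no measured step alters this oxygen; the one single-place step, a number 3 percentage points higher from compound 2 to compound 3 (within the scatter), concerns a saturated chain carbon and lies within the scatter, so it does not set the size of what is expected here. Compound 1, which carries no hydroxy, and compound 2, which does, differ in more than one place, yet their values show a wide gap. Compound 4 is therefore expected to show a loss of inhibition, with the step of a number 52.6 percentage points lower from compound 2 to compound 4 (beyond the scatter) estimated. The estimate for compound 4 in this assay is 40%, between 8% and 85%.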

Compound 4, a percentage reported as inhibition, at one concentration (the size of the read-out at that concentration, not a potency): 3.62%
For compound 4 the middle estimate is 36.4 percentage points above the measured one; measured number outside the range, below it.
By their numbers in this assay, from the lowest: compounds 4 and 1 (each within the scatter of the next); then compounds 2 and 3 (each within the scatter of the next).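

Among the compounds shown here, exchanging hydroxy for benzyloxy gives the first single-place step at this oxygen on an aromatic ring in this assay, and it is a large one: a number 89 percentage points lower from compound 2 to compound 4 (beyond the scatter). The earlier single-place step, a number 3 percentage points higher from compound 2 to compound 3 (within the scatter), concerned a saturated chain carbon and left this oxygen untouched, so it said nothing about this position, whereas this result shows that the read-out is highly sensitive to benzyl in place of the hydrogen here. Nothing available explains this loss of inhibition.

The compounds shown leave open whether the loss follows from any group on this oxygen or from benzyl in particular, a question that a methyl or an acetyl there would address. They also leave open whether an amine in place of the hydroxy would retain the inhibition of compound 2, at 92.6%.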